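Pyrazolopyrimidine enones in the HEK293 antiproliferation read-out

The source may report more compounds than this note shows. Statements on the series, on what has been measured and on what is new or still open speak of the compounds shown alone.

Measured so far:
compound 1 `COc1cc(C(=O)/C=C/c2cc(-c3cc(OC)c(OC)c(OC)c3)n3nc(-c4ccccc4)cc3n2)cc(OC)c1OC` — >= 100000 nM
compound 2 `COc1ccc(/C=C/C(=O)c2cc(-c3ccc(OC)c(OC)c3)n3nc(-c4ccccc4)cc3n2)cc1` — 50700 nM
compound 3 `COc1cc(-c2cc(/C=C/C(=O)c3ccc(C)cc3)nc3cc(-c4ccccc4)nn23)cc(OC)c1OC` — 50400 nM

In an ADME assay on HEK293 cells (Homo sapiens) for antiproliferative activity, read by MTT assay, with a stated time of 24 h (on this read-out lower numbers stand for stronger inhibition and higher numbers for weaker inhibition), compound 3 gives 50400 nM. Compound 2 gives 50700 nM in this assay, and the two numbers lie within the scatter of each other, so no order between them can be read. Compound 1 reaches only the limit of this assay, >= 100000 nM, and is a limit rather than a number.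

Compound 4 `COc1ccc(/C=C/C(=O)c2cc(-c3cc(OC)c(OC)c(OC)c3)n3nc(-c4ccccc4)cc3n2)cc1` is not yet measured. Relative to compound 3 the change is (2-(4-methoxyphenyl)ethenyl)carbonyl in place of 2-((4-methylphenyl)carbonyl)ethenyl on an aromatic carbon. Compound 2 carries the same (2-(4-methoxyphenyl)ethenyl)carbonyl group on a core bearing a dimethoxyphenyl group rather than the trimethoxyphenyl group of compound 4.

Among the measured compounds shown here, the one measured step that touches this part of the series is an at least 1.9-fold lower number from compound 1 to compound 3 (0.29 log units; that floor lies within the scatter). Its floor lies within the scatter, and the limit of >= 100000 nM in this assay, at which 1 of the 3 values shown sits, means the true size of that step is not known. For the measured compounds named here, no step in this set is resolved beyond the scatter, so no shift beyond the scatter is expected from compound 3 to compound 4, and the step is estimated as a 1.1-fold higher number from compound 3 to compound 4 (0.04 log units; within the scatter).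

Compound 4 is expected to give about 55000 nM in this assay, with a range from 20000 nM to 120000 nM.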

Compound 4, half-maximal inhibitory concentration: 46600 nM
Compound 4: the middle estimate sits 1.2-fold (0.07 log units) above what was measured; the measured number falls inside the stated range.
By their numbers in this assay, from the lowest: compounds 4, 3 and 2 (each within the scatter of the next). At a limit, above all of these: compound 1.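

On the aromatic carbon next to the ring nitrogen, (2-(4-methoxyphenyl)ethenyl)carbonyl in place of 2-((4-methylphenyl)carbonyl)ethenyl gives a 1.1-fold lower number from compound 3 to compound 4 (0.03 log units; within the scatter) in this assay. Among the compounds shown here, this is the first read of the exchange on a core that keeps the 3,4,5-trimethoxyphenyl group, and it shows that the whole exchange at this position, both the way the enone is attached to the core and the aryl group at its far end, leaves the read-out unresolved. Methoxy in place of hydrogen on an aromatic carbon gives a 1.1-fold lower number from compound 2 to compound 4 (0.04 log units; within the scatter), so the extra methoxy on the aryl group of the core is not resolved either, and no order can be read among compound 2, compound 3 and compound 4.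

On these data alone, the size of any difference involving compound 1 remains unknown, as its value is only a limit: the limit of >= 100000 nM in this assay, at which 1 of the 4 values shown sits. As far as these compounds go, whether an amine or a carboxylic acid on the far aryl ring of the enone, or a longer chain in place of the ethenyl link, would move the number beyond the scatter remains open.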